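Swapping a Small Ring for a Straight Chain

A few compounds are considered here, and "the series" means these few. Any claim that something is new, unique, unknown or untested is made for them only; others in the source may bear on it.

Of the compounds shown here, three built on one shared core have been measured. Compound 1 `O=S(=O)(/C=C/c1ccc(O)c(O)c1)CC1CC1`, compound 2 `O=S(=O)(/C=C/c1ccc(O)c(O)c1)CC1CCCCO1` and compound 3 `O=S(=O)(/C=C/c1ccc(O)c(O)c1)CCCCCCCCCO` differ only in the group attached to the saturated chain carbon bound to the sulfonyl sulfur. In a functional assay, read by fluorescence and spectrophotometry, with a stated time of 1 h (a lower number here means that less compound is needed, a higher number that more compound is needed for the effect), compound 1 gives 10500 nM, compound 2 gives 10800 nM and compound 3 gives 7500 nM. Compound 1 stands second highest of the three numbers; its nearest neighbour is compound 2 and its furthest is compound 3, and all three values lie within the scatter of one another.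

Compound 4 `CCCCCCCS(=O)(=O)/C=C/c1ccc(O)c(O)c1` has not yet been measured. It differs from compound 1 in one place: hexyl in place of cyclopropyl on a saturated chain carbon bound to a sulfonyl sulfur. Among the measured compounds shown here, the only measured step at this position, a 1.0-fold higher number from compound 1 to compound 2 (0.01 log units; within the scatter), shows that exchanging the ring for another ring left the number unchanged, and the straight-chain compound 3 sits within the scatter of compound 1 as well. A step of no real size is therefore expected, a 1.2-fold lower number from compound 1 to compound 4 (0.09 log units; within the scatter), and compound 4 is estimated at 8500 nM, within 4000 nM to 18000 nM.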

Compound 4, half-maximal effective concentration: 7100 nM
For compound 4 the middle estimate is 1.2-fold (0.08 log units) above the measured one; the measured number falls inside the stated range.
By their numbers in this assay, from the lowest: compounds 4, 3, 1 and 2 (each within the scatter of the next).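

In this assay, an open hexyl chain, with no ring, now stands in for a ring at the saturated chain carbon bound to the sulfonyl sulfur, and the result is a 1.5-fold lower number from compound 1 to compound 4 (0.17 log units; within the scatter) and a 1.5-fold lower number from compound 2 to compound 4 (0.18 log units; within the scatter). Hydrogen in place of 2-hydroxyethyl on the long chain gives a 1.1-fold lower number from compound 3 to compound 4 (0.02 log units; within the scatter), so removing the chain's hydroxyl group also produces no change beyond the scatter, and none of the four compounds stands apart from the others at this position. No measurement is available to explain why these different groups give such similar numbers.

Still open, from the compounds shown here alone, is whether an amine or a carboxylic acid on the chain, or a phenyl ring in place of the chain, would shift the number beyond the scatter. Also open, going by these compounds, is whether a change to the shared core would matter more than any change to this group.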